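The source may report more compounds than this note shows. Statements on the series, on what has been measured and on what is new or still open speak of the compounds shown alone.

Measured compounds:
compound 1 `CC(C)=CCN(C)C1CCN(CCCc2c[nH]c3ccc(-n4cnnc4)cc23)CC1` — 0.5 nM
compound 2 `c1ccc(CNCC2CCN(CCCc3c[nH]c4ccc(-n5cnnc5)cc34)CC2)cc1` — 1.6 nM
compound 3 `c1ccc(NCC2CCN(CCCc3c[nH]c4ccc(-n5cnnc5)cc34)CC2)nc1` — 1.7 nM

All three were tested in an assay on CHO cells for displacement of a labelled ligand from 5-hydroxytryptamine receptor 1D (Homo sapiens); on this read-out higher numbers stand for weaker inhibition and lower numbers for stronger inhibition. Compound 3 gives the highest of the three numbers; its gap to compound 2, a 1.1-fold higher number from compound 2 to compound 3 (0.03 log units; within the scatter), is within the scatter, whereas the step of a 3.4-fold higher number from compound 1 to compound 3 (0.53 log units; beyond the scatter) lies beyond it. Compound 4 `CN(Cc1ccsc1)C1CCN(CCCc2c[nH]c3ccc(-n4cnnc4)cc23)CC1` has not yet been measured. It differs from compound 3 in one place: methyl((thiophen-3-yl)methyl)amino in place of ((pyridin-2-yl)amino)methyl on a saturated ring carbon. Like compound 1, compound 4 thus carries a methyl-substituted amino group on the saturated ring carbon, so the step that bears on it is a 3.4-fold higher number from compound 1 to compound 3 (0.53 log units; beyond the scatter), which compound 4 is expected largely to reverse. Compound 4 is therefore expected to show a modest downward step, a 2.4-fold lower number from compound 3 to compound 4 (0.39 log units; beyond the scatter). Compound 4 is estimated at 0.7 nM, between 0.3 nM and 2 nM.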

Compound 4, half-maximal inhibitory concentration: 1.5 nM
Compound 4: the middle estimate sits 2.1-fold (0.33 log units) below what was measured, and the stated range covers the measured number.
By their numbers in this assay, from the lowest: compound 1; then compounds 4, 2 and 3 (each within the scatter of the next).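

In this assay, a methyl-substituted amino group on the saturated ring carbon does not alone restore the number of compound 1: with thiophen-3-yl in place of 2-methylprop-1-en-1-yl on the chain, the step stays beyond the scatter (a 3.0-fold higher number from compound 1 to compound 4 (0.48 log units; beyond the scatter)). Losing the hydrogen-bond donor of ((pyridin-2-yl)amino)methyl leaves the number within the scatter (a 1.1-fold lower number from compound 3 to compound 4 (0.05 log units; within the scatter)), and the comparison with the benzylamino compound is likewise within it (a 1.1-fold lower number from compound 2 to compound 4 (0.03 log units; within the scatter)). No measurement shown accounts for these steps. Open, on these data alone, is whether furan-3-yl or phenyl in place of thiophen-3-yl would move the number, and whether a simple ethyl on that amine nitrogen would matter.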